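From a Vinyl Group to a Furan Ring

The compounds below may be only part of what the source reports. "The series", "measured", "known", "first", "only" and "open" are said of these compounds alone.

In a functional assay on CUTLL1 cells (Homo sapiens) for inhibition, read by resazurin assay, with a stated time of 48 h, in the presence of a further agent that is not named here (a lower number here means that less compound is needed, a higher number that more compound is needed for the effect), compound 1 `COc1ccc(-c2cnc(N)nc2C2CC2)cc1` gives > 100000 nM as a limit of the assay and not a number. Within the data shown here, compound 2 `C=Cc1cnccc1-c1cnc(N)nc1C1CC1` gives 29000 nM and so holds the only actual number so far, with no second number to rank it against.

Compound 3 `Nc1ncc(-c2ccncc2-c2ccoc2)c(C2CC2)n1` has not yet been measured. It is reached from compound 2 by furan-3-yl in place of vinyl on an aromatic carbon and carries furan-3-yl in place of vinyl on an aromatic carbon, ortho to a large group. Among the measured compounds shown here, no measured step shows what such a swap does in this assay and the sole anchor is compound 2 at 29000 nM in this read-out. A small move towards less compound needed is therefore expected, perhaps not much beyond the usual scatter. The expected change is a 1.9-fold lower number from compound 2 to compound 3 (0.29 log units; within the scatter) and remains only an estimate. For compound 3 the estimated half-maximal effective concentration is 15000 nM with an expected range from 3000 nM to 70000 nM before any measurement.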

Compound 3, half-maximal effective concentration: 28000 nM
For compound 3 the middle estimate is 1.9-fold (0.27 log units) below the measured one; measured number inside the range.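

Among these compounds, the first step that can be read at this position, in this assay, is a 1.0-fold lower number from compound 2 to compound 3 (0.02 log units; within the scatter), for furan-3-yl in place of vinyl. The larger group, a five-membered aromatic ring with a hydrogen-bond acceptor, can therefore stand on this aromatic carbon, ortho to a large group, and compound 2 and compound 3 cannot be told apart by their numbers. Compound 1 remains a limit of the assay and not a number: the limit of > 100000 nM in this assay, at which 1 of the 3 values shown sits.

As far as these compounds go, whether another kind of group here, such as an amine, a carboxylic acid or a longer chain, would give a step beyond the scatter remains open. A phenyl ring in the same place would show whether the oxygen of the furan ring matters at all.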